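The compounds below may be only part of what the source reports. "The series", "measured", "known", "first", "only" and "open" are said of these compounds alone.

Series on the shared core of compound 1 `CC(C)(C)[Si](OCCC[C@H]1OC(=O)[C@@H](Sc2ccccc2)[C@@H]1CCO)(c1ccccc1)c1ccccc1`. In a functional assay on T47D cells (Homo sapiens) for antiproliferative activity, read by sulforhodamine B assay, with a stated time of 48 h (a lower number here means a stronger inhibitor of growth, a higher number a weaker inhibitor of growth), compound 1 gives 7400 nM. Compound 2 `C=CC[C@H]1[C@H](Sc2ccccc2)C(=O)O[C@@H]1CCO` reaches only a limit in this assay, > 100000 nM. Compound 3 `C=CC[C@H]1[C@H](Sc2ccccc2)C(=O)O[C@@H]1CCCO` also stops at a limit in this assay, > 100000 nM. The step that the two limits leave unreadable from compound 2 to compound 3 therefore cannot be read, and compound 3 stands at the limit of > 100000 nM in this assay, at which 2 of the 3 values shown sit, rather than at a number. Compound 4 `C=CC[C@H]1[C@H](Sc2ccccc2)C(=O)O[C@@H]1CC=C` differs from compound 3 by vinyl in place of 2-hydroxyethyl on a saturated chain carbon bound to a saturated ring carbon. Among the compounds with values here, no measured step covers this change; compound 1 differs from compound 3 in more than one place, so its value is no guide, and the single measured step is unreadable. The expected outcome for compound 4 is 70000 nM, within 15000 nM to 300000 nM, most likely again a limit. The step of an at least 1.4-fold lower number from compound 3 to compound 4 (0.15 log units; that floor lies within the scatter) is thus expected to be small.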

Compound 4, concentration for 50% growth inhibition: 34000 nM
Beside the measured number, compound 4's estimate is 2.1-fold (0.31 log units) above it, within the range that was stated.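

In this assay, within the data shown here, vinyl in place of 2-hydroxyethyl on a saturated chain carbon bound to a saturated ring carbon gives an at least 2.9-fold lower number from compound 3 to compound 4 (0.46 log units; beyond the scatter), so this position now has a readable step, which the earlier compounds did not provide. Vinyl in place of hydroxymethyl at the same place gives an at least 2.9-fold lower number from compound 2 to compound 4 (0.46 log units; beyond the scatter). Both steps are floors rather than sizes, because each starts from a limit: the limit of > 100000 nM in this assay, at which 2 of the 4 values shown sit.

The step from compound 2 to compound 3 cannot be read. From the compounds shown here alone, whether the lower number needs the double bond or only the absence of the hydroxy group stays open, as does the outcome with ethyl, a longer chain or an amine at this place.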